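A few compounds are considered here, and "the series" means these few. Any claim that something is new, unique, unknown or untested is made for them only; others in the source may bear on it.

Measured in a functional assay on SW480 cells (Homo sapiens) for cytotoxicity, read by MTT assay, with a stated time of 24 h; on this read-out lower numbers stand for stronger inhibition and higher numbers for weaker inhibition:
compound 1 `C=CC1=C(C(=O)Nc2ccccc2)C(c2ccc(Cl)c(Cl)c2)OC1` gives > 100000 nM, a limit of the assay.
compound 2 `C=CC1=C(C(=O)NC2CCCCC2)C(c2ccc(OC)cc2)OC1` gives > 100000 nM, a limit of the assay.
compound 3 `C=CC1=C(C(=O)NCc2ccccc2)C(c2ccc(Cl)c(Cl)c2)OC1` gives > 100000 nM, a limit of the assay.

Compound 3 thus stands at the limit in this assay, with no number of its own. The other measured compounds give no number either; (the limit of > 100000 nM in this assay, at which 3 of the 3 values shown sit). Among the measured compounds shown here, the only measured step, a step that the two limits leave unreadable from compound 1 to compound 3, has no readable size: both of its ends are limits. Compound 4 `C=CC1=C(C(=O)NCc2ccccc2)C(c2ccc(OC)cc2)OC1` differs from compound 3 in one place: 4-methoxyphenyl in place of 3,4-dichlorophenyl on a saturated ring carbon. For the measured compounds named here, no measured step bears on this change; compound 2, which also carries the 4-methoxyphenyl group, sits at the same limit. The expected step is therefore a step that the limit leaves unreadable from compound 3 to compound 4, with no direction beyond the scatter. Compound 4 is estimated at 200000 nM, between 100000 nM and 1000000 nM, most likely again reported only as a limit.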

Compound 4, half-maximal inhibitory concentration: 39500 nM
Compound 4: middle estimate off by 5.1-fold (0.70 log units), on the high side, outside the stated range (below it).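

Replacing 3,4-dichlorophenyl with 4-methoxyphenyl on the saturated ring carbon gives an at least 2.5-fold lower number from compound 3 to compound 4 (0.40 log units; beyond the scatter), so a change at this position can bring a compound off the limit when the amide nitrogen carries benzyl. The amide group matters too: with 4-methoxyphenyl kept, benzyl in place of cyclohexyl gives an at least 2.5-fold lower number from compound 2 to compound 4 (0.40 log units; beyond the scatter). Among these compounds, only the pairing in compound 4 leaves the limit: the limit of > 100000 nM in this assay, at which 3 of the 4 values shown sit.

On these data alone, how far compound 2 and compound 3 lie beyond that limit remains unknown, so both steps have no upper size. Also open, as far as these compounds go, is whether 4-aminophenyl on that ring carbon, or a longer chain on the amide nitrogen, would lower the number further.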